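Swapping methoxy for fluoro on a shared core

The source may report more compounds than this note shows. Statements on the series, on what has been measured and on what is new or still open speak of the compounds shown alone.

Measured compounds:
- Compound 1, `Cc1ccc(-c2cs/c(=N/NC(=O)CSc3nnnn3-c3ccccc3)n2-c2ccccc2)cc1`: 14.7 ug/mL
- Compound 2, `COc1ccc(-c2cs/c(=N/NC(=O)CSc3nnnn3-c3ccccc3)n2-c2ccccc2)cc1`: "not determined" (no result reported)
- Compound 3, `COc1ccc(-c2cs/c(=N/NC(=O)CSc3ncccn3)n2-c2ccccc2)cc1`: 102 ug/mL

Three compounds share most of their structure. In a functional assay on C6 cells (Rattus norvegicus) for cytotoxicity, read by MTT assay, with a stated time of 24 h (on this read-out lower numbers stand for stronger inhibition and higher numbers for weaker inhibition), compound 1 gives 14.7 ug/mL. Compound 3 differs from compound 2 in a part of the molecule away from the substituted ring, and in this assay compound 3 gives 102 ug/mL. Compound 2, the starting point for the step considered here, has no single number in this assay, where for compound 2 the entry reads "not determined" (no result reported), so its standing among these compounds can only be guessed from its neighbours: compound 1 carries the same remaining structure and is the closer guide.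

Compound 4, `O=C(CSc1nnnn1-c1ccccc1)N/N=c1/scc(-c2ccc(F)cc2)n1-c1ccccc1`, has not been measured. Its difference from compound 2 is fluoro in place of methoxy on an aromatic carbon. For the measured compounds named here, no measured pair shows this change directly, so no size is fixed for it. Because compound 1 gives 14.7 ug/mL with only a small group on that ring, a step of about the scatter or little beyond it, in either direction, is expected. Compound 4 is therefore estimated at 25 ug/mL, within a range of 8 ug/mL to 80 ug/mL.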

Compound 4, half-maximal inhibitory concentration: 24.3 ug/mL
The estimate for compound 4 lay 1.0-fold (0.01 log units) above the measured number; the range from low to high includes it.
By their numbers in this assay, from the lowest: compounds 1 and 4 (each within the scatter of the next); then compound 3.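

In this assay, for the compounds shown here, fluoro in place of methyl gives a 1.7-fold higher number from compound 1 to compound 4 (0.22 log units; within the scatter) and so gives the first readable comparison at this position on the ring. On this evidence, the two small groups cannot be told apart in this assay, and the position accepts either with a number inside the usual scatter. Compound 2 has no reported number, so the step from it to compound 4 cannot be read, and nothing here ties the result to a measured property of either group.

On these data alone, what a methoxy group itself does at this position remains open. As far as these compounds go, it is also open whether an amine, a carboxylic acid or a longer carbon chain on the same aromatic carbon would leave the number unchanged or move it beyond the scatter.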